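A trifluoromethyl step from a limit on compound 2

A few compounds are considered here, and "the series" means these few. Any claim that something is new, unique, unknown or untested is made for them only; others in the source may bear on it.

The shared core carries an amide-bearing propenyl chain on a five-membered heteroaromatic ring with an aryl substituent. In a functional assay on HO8910 cells (Homo sapiens) for cytotoxicity, read by CCK-8 assay, with a stated time of 24 h (on this read-out lower numbers stand for stronger inhibition and higher numbers for weaker inhibition), compound 1 `C/C(=C\c1ccc(-c2ccc(C)cc2)o1)C(N)=O` gives 1660 nM. Compound 2 `C/C(=C\c1cc(-c2ccccc2)cs1)C(N)=O` gives only a limit in this assay, > 50000 nM, so its true value is not known. Compound 3 `C/C(=C\c1cc(-c2ccccc2C)cs1)C(N)=O` gives 15200 nM in this assay. Going by the values given here, the one step measured between neighbours, an at least 3.2-fold lower number from compound 2 to compound 3 (0.51 log units; beyond the scatter), shows that substitution on the six-membered ring can bring the number out from the limit of > 50000 nM in this assay, at which 1 of the 3 values shown sits.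

Compound 4 `C/C(=C\c1cc(-c2ccc(C(F)(F)F)cc2)cs1)C(N)=O` differs from compound 2 by trifluoromethyl in place of hydrogen on an aromatic carbon. Among the compounds with values here, this is the only measured step that bears on the change, and it is at least modest in the direction of a lower number; a trifluoromethyl in this place is otherwise untested here, and compound 1 with its furan core is not a neighbour of compound 2. The writer therefore expects a step of similar size, an at least 2.5-fold lower number from compound 2 to compound 4 (0.39 log units; beyond the scatter), though with a real chance that compound 4 also returns only a limit. The expected value for compound 4 in this assay is 20000 nM, between 5000 nM and 60000 nM.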

Compound 4, half-maximal inhibitory concentration: > 50000 nM
Compound 4 gave a limit, no number; the forecaster's own chance of this, stated with the estimate: 30%; middle value at least 2.5-fold (0.39 log units) from the limit.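

Compound 4 returns only a limit in this assay, > 50000 nM, and not a number. Compound 2 also stands at a limit, so the step between compound 2 and compound 4 cannot be read. The compounds shown leave open whether trifluoromethyl in place of hydrogen on the aromatic carbon changes the number at all, and by how much.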